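From hydroxy to (1-phenylethyl)amino: tolerance notes

The source may report more compounds than this note shows. Statements on the series, on what has been measured and on what is new or still open speak of the compounds shown alone.

Measured in an ADME assay on HEK-293T cells (Homo sapiens) for cytotoxicity, read by luminescence, with a stated time of 24 h; a higher number here means that more compound is tolerated, a lower number that less compound is tolerated:
- compound 1 `CCCNCc1cc2c(cc(C(=O)N3CCC(C(=O)NCCC)CC3)n2Cc2ccc(OC)cc2)s1`: > 100000 nM (a limit)
- compound 2 `CCCNC(=O)C1CCN(C(=O)c2c(Br)c3sccc3n2Cc2ccc(OC)cc2)CC1`: 31600 nM
- compound 3 `CCCNC(=O)C1CCN(C(=O)c2c(CO)c3sccc3n2Cc2ccc(OC)cc2)CC1`: > 100000 nM (a limit)

Compound 3 stands at the limit of > 100000 nM in this assay, at which 2 of the 3 values shown sit, so it has no exact number on this scale. Any step away from it can be judged only against that limit.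

Compound 4 `CCCNC(=O)C1CCN(C(=O)c2c(CNC(C)c3ccccc3)c3sccc3n2Cc2ccc(OC)cc2)CC1` differs from it in one place: (1-phenylethyl)amino in place of hydroxy on a saturated chain carbon bound to an aromatic carbon. In words, (1-phenylethyl)amino replaces hydroxy on a saturated chain carbon bound to an aromatic carbon. Cut one bond further out, this reads hydroxymethyl to ((1-phenylethyl)amino)methyl.

Within the data shown here, only one measured step bears on this group: an at least 3.1-fold higher number from compound 2 to compound 3 (0.50 log units; beyond the scatter). That step shows that a change here can move the read-out in this assay beyond the scatter. Among the measured compounds shown here, it does not cover the entering group, and no measured compound carries it. For the measured compounds named here, compound 2, the only compound with an exact number, gives 31600 nM, which serves as a rough guide to where a compound without hydroxymethyl may fall.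

A moderate move towards less compound tolerated is therefore expected, and another limit remains possible. The expected step is an at least 2.0-fold lower number from compound 3 to compound 4 (0.30 log units; that floor lies within the scatter). For compound 4 the estimated half-maximal cytotoxic concentration is 50000 nM, with an expected range of 15000 nM to 100000 nM.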

Compound 4, half-maximal cytotoxic concentration: 57500 nM
Estimate against measurement, compound 4: 1.2-fold (0.06 log units) below; measured number inside the range.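

In this assay, compound 4 gives an exact reading at a place where hydroxymethyl gave only a limit, so this position now has a second exact number alongside that of the bromo compound. Set against that bromo compound, the reading is a 1.8-fold higher number from compound 2 to compound 4 (0.26 log units; within the scatter), so ((1-phenylethyl)amino)methyl, with its six-membered aromatic ring of carbon only, can enter here and leave the read-out level with bromo on this scale. Set against hydroxymethyl, the result is an at least 1.7-fold lower number from compound 3 to compound 4 (0.24 log units; that floor lies within the scatter), and this step has only a floor, which does not establish a real loss of tolerance, because the value of compound 3 is a limit and not a number: the limit of > 100000 nM in this assay, at which 2 of the 4 values shown sit.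

Going by these compounds, whether the aromatic ring, the branching methyl or the nitrogen of the entering group decides the reading stays open, and a plain amino group, a methylamino group or a benzylamino group in the same place would separate these parts. Among these compounds, also open is how far hydroxymethyl and ((1-phenylethyl)amino)methyl truly lie apart, since only one side of that step has an exact number.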